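This account rests on a few compounds, and the source may have more. Where it says the series, first, only, none or still open, it means among the compounds named here.

Measured in a functional assay on A-375 cells (Homo sapiens) for inhibition, read by CCK-8 assay, with a stated time of 72 h; a higher number here means a weaker inhibitor, a lower number a stronger inhibitor:
- compound 1 `Nc1ccccc1NC(=O)c1ccc(CNC(=O)c2n[nH]cc2NC(=O)c2ccccc2)cc1`: 1590 nM
- compound 2 `Nc1ccccc1NC(=O)c1ccc(CNC(=O)c2n[nH]cc2NC(=O)c2ccccc2F)cc1`: 2270 nM

Within the data shown here, compound 2, at 2270 nM, is one of only two measured values and cannot be separated from the other. The step between them is a 1.4-fold higher number from compound 1 to compound 2 (0.15 log units; within the scatter), so no order can be drawn.

Compound 3 `Nc1ccccc1NC(=O)c1ccc(CNC(=O)c2n[nH]cc2NC(=O)c2c(F)cccc2F)cc1` has not yet been measured. It differs from compound 2 by fluoro in place of hydrogen on an aromatic carbon. In words, this is fluoro in place of hydrogen on an aromatic carbon, turning 2-fluorophenyl into 2,6-difluorophenyl.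

Among the measured compounds shown here, only one measured step bears on this change, the same exchange made once before on the same ring: a 1.4-fold higher number from compound 1 to compound 2 (0.15 log units; within the scatter). One step is thin evidence, and the data do not show how a second fluoro behaves when a first is already present. Even so, that step gives no reason to expect a shift beyond the scatter in this assay, in either direction.

The expected step is a 1.1-fold higher number from compound 2 to compound 3 (0.02 log units; within the scatter). For compound 3 the estimated value is 2400 nM, with an expected range of 1100 nM to 5000 nM.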

Compound 3, half-maximal inhibitory concentration: 1700 nM
For compound 3 the middle estimate is 1.4-fold (0.15 log units) above the measured one; low and high end bracket the measured number.
By their numbers in this assay, from the lowest: compounds 1, 3 and 2 (each within the scatter of the next).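

In this assay the second fluoro gives a 1.3-fold lower number from compound 2 to compound 3 (0.13 log units; within the scatter) and so, like the first, does not move the number beyond the scatter, and the whole exchange of phenyl for 2,6-difluorophenyl on the carbonyl carbon gives a 1.1-fold higher number from compound 1 to compound 3 (0.03 log units; within the scatter) and stays within it as well. Among these compounds, the position therefore now holds no fluoro, one fluoro or two fluoro groups without any readable difference, which the single earlier step could not show, and compounds 1, 2 and 3 cannot be put in an order. No measurement is at hand that would explain why these numbers stay so close.

Still open, going by these compounds, is whether any group other than fluoro on this ring, such as chloro, methoxy, an amine or a carboxylic acid, would produce a step beyond the scatter in this assay at all. The three compounds also leave open how far the number depends on this ring rather than on the shared core, which is the same in all of them, and whether a longer chain in place of the phenyl on the carbonyl carbon would change it.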